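This account rests on a few compounds, and the source may have more. Where it says the series, first, only, none or still open, it means among the compounds named here.

Working notes on the series, followed in a physicochemical assay for lipophilicity, at pH 7.4; on this read-out higher numbers stand for higher lipophilicity and lower numbers for lower lipophilicity. Of the compounds shown here, two have numbers so far. Compound 1 `Cc1c(C(C)OC(=O)Nc2ccccc2)oc2ncnn12` gives 2.3, the lower of the two, and compound 2 `Cc1c(C(C)OC(=O)Nc2cccc(Cl)c2)oc2ncnn12` gives 2.9. The next structure is compound 3 `Cc1c(C(C)OC(=O)Nc2ccccc2)oc2nc(-c3cccs3)nn12`, which differs from compound 1 in one place: thiophen-2-yl in place of hydrogen on an aromatic carbon. Thiophen-2-yl replaces hydrogen on an aromatic carbon of the five-membered aromatic ring with 3 nitrogen, between two ring nitrogen atoms.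

Among the measured compounds shown here, only one measured step is available as a guide: a number 0.60 log units higher from compound 1 to compound 2 (beyond the scatter), a modest rise beyond the scatter, for chloro in place of hydrogen on an aromatic carbon. For the measured compounds named here, that step involves a different group at a different place, and no measured step touches the place changed in compound 3, so it gives only a rough guide to direction and size. Going by a number 0.60 log units higher from compound 1 to compound 2 (beyond the scatter) for compound 2, a rise in the same direction is expected, somewhat larger. The estimated step is a number 0.90 log units higher from compound 1 to compound 3 (beyond the scatter). For compound 3 the expected value is 3.2, with an estimated range of 2.7 to 3.7.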

Compound 3, distribution coefficient: 3.7
Beside the measured number, compound 3's estimate is 0.50 log units below it, and the stated range covers the measured number.
By their numbers in this assay, from the lowest: compound 1; then compound 2; then compound 3.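

In this assay, the place on the five-membered aromatic ring with 3 nitrogen, between two ring nitrogen atoms, now has its first reading, and it responds strongly to substitution: thiophen-2-yl in place of hydrogen gives a number 1.40 log units higher from compound 1 to compound 3 (beyond the scatter), a large step. Among the compounds shown here, the only earlier step, a number 0.60 log units higher from compound 1 to compound 2 (beyond the scatter), is modest, but it belongs to chloro at another place, so the difference in size cannot be assigned to the group or to the place alone. The data on hand offer no measured explanation for the size of the new step.

Thiophen-2-yl is the only group read at this place, so it remains open whether a small group such as methyl, an amine or a carboxylic acid would move the number in the same direction or by a similar amount. Going by these compounds, it is also open whether the chloro and thiophen-2-yl steps would add up in a single compound carrying both groups on the core of compound 1.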